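The source may hold more compounds than are shown below. What is called first, only, known or untested is meant among the compounds shown, and "the series" means these compounds.

Compound 1 `O=C(CC1c2ccccc2N=C(N2CCCCC2)N1c1ccccc1)NCc1ccccc1`: 90.1%
Compound 2 `O=C(CC1c2ccccc2N=C(N2CCOCC2)N1c1ccccc1)NCc1ccccc1`: 40.5%

Both compounds were tested in a functional assay on HEK293 cells for inhibition of Voltage-dependent T-type calcium channel subunit alpha-1G (Homo sapiens), tested at 10 uM; on this read-out lower numbers stand for less inhibition and higher numbers for more inhibition at the one concentration tested (going by the name of the read-out). Compound 1 stands highest of the two numbers; its nearest neighbour, compound 2, lies a number 49.6 percentage points lower from compound 1 to compound 2 (beyond the scatter), a large step that goes with morpholin-4-yl in place of piperidin-1-yl on a carbon with a double bond to nitrogen.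

Compound 3 `Nc1ccc(CNC(=O)CC2c3ccccc3N=C(N3CCCCC3)N2c2ccccc2)cc1` has not been measured yet. It differs from compound 1 by amino in place of hydrogen on an aromatic carbon. Within the data shown here, this change sits on the benzyl part of the molecule, far from the ring where compound 1 and compound 2 differ, so no measured step bears directly on it. With the shared core and the piperidin-1-yl group of compound 1 kept, compound 3 is expected to stay close to compound 1, with a step of a number 8.1 percentage points lower from compound 1 to compound 3 (within the scatter) that may fall within the scatter. Compound 3 is therefore estimated at 82%, in a range from 55% to 97%.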

Compound 3, a percentage reported as inhibition, at one concentration (the size of the read-out at that concentration, not a potency): 43.5%
For compound 3 the middle estimate is 38.5 percentage points above the measured one; the whole stated range lies above it.
By their numbers in this assay, from the lowest: compounds 2 and 3 (each within the scatter of the next); then compound 1.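

The benzyl end of the molecule turns out to matter in this assay: changing benzyl to 4-aminobenzyl adds a single heavy atom, yet it gives a number 46.6 percentage points lower from compound 1 to compound 3 (beyond the scatter). Among these compounds, the earlier pair showed a large step only at the piperidin-1-yl group, so this is the first sign that inhibition at this one concentration also depends on the far end of the molecule. Nothing available here accounts for the size of this step.

The compounds shown leave open whether any group at this place would give such a step or whether it is specific to amino, which a methoxy group, a fluorine atom or a carboxylic acid on the same carbon could help settle. Also open, from the compounds shown here alone, is what the same amino group would do in compound 2, which carries morpholin-4-yl.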